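The source may hold more compounds than are shown below. What is called first, only, known or untested is meant among the compounds shown, and "the series" means these compounds.

Working notes on the series. In a functional assay on MDA-MB-231 cells (Homo sapiens) for antiproliferative activity, read by MTT assay, with a stated time of 72 h (a lower number here means a stronger inhibitor, a higher number a weaker inhibitor), compound 1 `CC(=O)Oc1ccccc1C(=O)OCC[Se]C#N` stands as the higher of the two numbers: compound 1 gives 34300 nM, while compound 2 `CC(=O)Oc1ccccc1C(=O)[Se]CC[Se]C(=O)c1ccccc1OC(C)=O` gives 7600 nM, a gap beyond the usual scatter. Compound 3 `CC(=O)Oc1ccccc1C(=O)NCCSC#N` has not been measured; it differs from compound 1 by a group of 6 heavy atoms (3 carbon, 2 nitrogen, 1 sulfur; no ring) in place of a group of 6 heavy atoms (3 carbon, 1 nitrogen, 1 oxygen, 1 selenium; no ring), on a carbonyl carbon. Among the compounds with values here, no measured pair shows this change, and both measured compounds carry selenium whereas compound 3 carries none. A modest step toward a weaker inhibitor is therefore expected, a 1.7-fold higher number from compound 1 to compound 3 (0.24 log units; within the scatter). For compound 3 in this assay the estimate is 60000 nM, with a range from 20000 nM to 200000 nM.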

Compound 3, half-maximal inhibitory concentration: > 50000 nM
Compound 3: a limit, no number; the forecaster's own chance of this, stated with the estimate: 25%; the middle value lies beyond the limit too.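

In this assay compound 3 gives > 50000 nM, a limit and not a number. The change on a carbonyl carbon to (2-(cyanosulfanyl)ethyl)amino can therefore be read only as a floor, an at least 1.4-fold higher number from compound 1 to compound 3 (0.16 log units; that floor lies within the scatter), and that floor does not separate the two compounds. The reading rests on a single compound: the limit of > 50000 nM in this assay, at which 1 of the 3 values shown sits.

Oxygen and selenium leave and nitrogen and sulfur enter in one step, so the compounds shown leave open which atom carries it. A compound pairing the amide nitrogen with selenium, or one with a longer chain, would help separate these.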